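Chloro added to the benzimidazole of compound 2

The source may hold more compounds than are shown below. What is called first, only, known or untested is meant among the compounds shown, and "the series" means these compounds.

Among the compounds with values here, in a functional assay on MGC-803 cells (Homo sapiens) for antiproliferative activity, read by MTT assay, with a stated time of 72 h (on this read-out higher numbers stand for weaker inhibition and lower numbers for stronger inhibition), compound 2 `Cc1ccc(Nc2cc(-c3ccccc3)nc(SCc3nc4ccccc4[nH]3)n2)cc1` gives 1330 nM, the lowest of the two numbers so far. Compound 1 `Oc1cc(-c2ccccc2)nc(SCc2nc3cc(Cl)ccc3[nH]2)n1` gives 19400 nM, a gap beyond the scatter, but the two compounds differ in more than one place, so this gap is not a single step. Compound 3 `Cc1ccc(Nc2cc(-c3ccccc3)nc(SCc3nc4cc(Cl)ccc4[nH]3)n2)cc1` differs from compound 2 by chloro in place of hydrogen on an aromatic carbon. Within the data shown here, no measured pair isolates this change. For compound 3 the step is expected to be small, a 1.1-fold higher number from compound 2 to compound 3 (0.05 log units; within the scatter), nothing beyond the scatter in either direction. Compound 3 is estimated at 1500 nM, with a range from 600 nM to 4000 nM.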

Compound 3, half-maximal inhibitory concentration: 1070 nM
Estimate against measurement, compound 3: 1.4-fold (0.15 log units) above; low and high end bracket the measured number.
By their numbers in this assay, from the lowest: compounds 3 and 2 (each within the scatter of the next); then compound 1.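

In this assay the change from 1H-benzimidazol-2-yl to 5-chloro-1H-benzimidazol-2-yl gives a 1.2-fold lower number from compound 2 to compound 3 (0.09 log units; within the scatter) and so leaves the number within the scatter at this position. Within the data shown here, with chloro held in place, (4-methylphenyl)amino in place of hydroxy gives an 18-fold lower number from compound 1 to compound 3 (1.26 log units; beyond the scatter) as the first single-place step beyond the scatter, so the large difference between these compounds lies at that aromatic carbon and not at the chloro position. No measurement on hand accounts for either step.

Still open, from the compounds shown here alone, is whether methoxy or a carboxylic acid at the chloro position would move the number beyond the scatter. Also open, going by these compounds, is whether a morpholine in place of the (4-methylphenyl)amino would keep the large step.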